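A few compounds are considered here, and "the series" means these few. Any claim that something is new, unique, unknown or untested is made for them only; others in the source may bear on it.

Three compounds built on a shared core have been examined in an ADME assay on L02 cells (Homo sapiens) for antiproliferative activity, read by MTT assay, with a stated time of 48 h; on this read-out lower numbers stand for stronger inhibition and higher numbers for weaker inhibition. Compound 1 `N#CC1=C(N)Oc2c(c3nc4ccccc4nc3c3ccccc23)C12C(=O)N(Cc1cnnn1-c1ccccc1Cl)c1ccccc12` returns only the limit of the assay, > 50000 nM. Compound 2 `N#CC1=C(N)Oc2c(c3nc4ccccc4nc3c3ccccc23)C12C(=O)N(Cc1cnnn1-c1ccc(Br)cc1)c1ccccc12` likewise returns the assay limit, > 50000 nM. Compound 3 `N#CC1=C(N)Oc2c(N)cc3nc4ccccc4nc3c2C12C(=O)N(Cc1cnnn1-c1cccc(C(F)(F)F)c1)c1ccccc12` is the only one of the three to give a number, and in this assay compound 3 gives 38100 nM. The step that the two limits leave unreadable from compound 1 to compound 2 cannot be sized because both of its values sit at the limit of > 50000 nM in this assay, at which 2 of the 3 values shown sit.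

Compound 4 `CCc1cccc(CC)c1-n1nncc1CN1C(=O)C2(C(C#N)=C(N)Oc3c(N)cc4nc5ccccc5nc4c32)c2ccccc21` differs from compound 3 by 2,6-diethylphenyl in place of 3-(trifluoromethyl)phenyl on an aromatic nitrogen. For the measured compounds named here, the one measured step that also alters the group on that aromatic nitrogen, from compound 1 to compound 2, has no readable size, so no measured step offers guidance on this change. Compound 3 already lies close to the assay limit. Compound 4 is therefore expected to remain in the same region, with a step of a 1.2-fold higher number from compound 3 to compound 4 (0.07 log units; within the scatter) expected to stay within the scatter. The estimate for compound 4 in this assay is 45000 nM, with a range from 20000 nM to 120000 nM.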

Compound 4, half-maximal inhibitory concentration: > 50000 nM
Compound 4: no number, only a limit (the forecaster's own chance of this, stated with the estimate: 50%); middle value at least 1.1-fold (0.04 log units) from the limit.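

Replacing 3-(trifluoromethyl)phenyl with 2,6-diethylphenyl, two groups with the same number of heavy atoms, on the aromatic nitrogen of the five-membered ring gives an at least 1.3-fold higher number from compound 3 to compound 4 (0.11 log units; that floor lies within the scatter) in this assay. For the compounds shown here, this is the first step at this position with any readable size, but it is only a floor, and the full size of the change cannot be read. Compound 4 gives no number, only the limit of the assay, so the swap does not bring a value clear of that limit: the limit of > 50000 nM in this assay, at which 3 of the 4 values shown sit.

The compounds shown leave open how far compound 4 lies past the limit. They also leave open whether a phenyl group carrying an amine or a carboxylic acid on this aromatic nitrogen would give a number, and on which side of compound 3 it would fall.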